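This account rests on a few compounds, and the source may have more. Where it says the series, first, only, none or still open, it means among the compounds named here.

Compound 1 `CC(C)=CCC/C(C)=C/CC1Cc2c(O)cc(=O)n(CCCO)c2CC1(C)C` is the parent of the pair; in a functional assay on PANC-1 cells (Homo sapiens) for inhibition, read by MTT assay, with a stated time of 24 h, tested at 10 uM (a higher number here means more inhibition at the concentration tested (going by the name of the read-out), a lower number less inhibition), compound 1 gives 28.7%. Compound 2 `CC(C)=CCC/C(C)=C/CC1Cc2c(OC(=O)Nc3cccc(F)c3)cc(=O)n(CCCO)c2CC1(C)C` carries (3-fluorophenyl)carbamoyl in place of hydrogen on an oxygen on an aromatic ring, and in this assay compound 2 gives 52.3%. That single change reads a number 23.6 percentage points higher from compound 1 to compound 2 (beyond the scatter), so on the two numbers available compound 2 stands highest, with compound 1 as its nearest neighbour. Compound 3 `CC(C)=CCC/C(C)=C/CC1Cc2c(OC(=O)Nc3ccc(Cl)cc3)cc(=O)n(CCCO)c2CC1(C)C` keeps the carbamate and differs from compound 2 in one place: 4-chlorophenyl in place of 3-fluorophenyl on an amide-type nitrogen. Among the measured compounds shown here, no measured step exchanges one substituted phenyl for another; the only known step, from compound 1 to compound 2, concerns the carbamoyl group itself and bears on this change only loosely. With nothing to point either way, the expected step in this assay is a number 0.3 percentage points lower from compound 2 to compound 3 (within the scatter), none beyond the scatter. Compound 3 is therefore estimated at 52%, within 35% to 68%.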

Compound 3, a percentage reported as inhibition, at one concentration (the size of the read-out at that concentration, not a potency): 47.2%
The estimate for compound 3 lay 4.8 percentage points above the measured number; the range from low to high includes it.
By their numbers in this assay, from the lowest: compound 1; then compounds 3 and 2 (each within the scatter of the next).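

In this assay, 4-chlorophenyl in place of 3-fluorophenyl on the amide-type nitrogen gives a number 5.1 percentage points lower from compound 2 to compound 3 (within the scatter), so this pair does not separate the two substituted phenyl groups. The gain over the parent now stands with a second carbamate, a number 18.5 percentage points higher from compound 1 to compound 3 (beyond the scatter), next to a number 23.6 percentage points higher from compound 1 to compound 2 (beyond the scatter), and holds for both carbamates shown. Nothing available accounts for either step.

On these data alone, it remains open whether an unsubstituted phenyl, a 4-methoxyphenyl or a cyclohexyl group on this nitrogen would stay at the level of compound 2 and compound 3. As far as these compounds go, it is equally open whether the gain needs the carbamate at all, or whether a plain acetyl ester on the same oxygen would give a similar reading.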